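The compounds below may be only part of what the source reports. "The series", "measured", "known", "first", "only" and "open" are said of these compounds alone.

Measured so far in a functional assay on ME-180 cells (Homo sapiens) for cytotoxicity, read by MTT assay, with a stated time of 72 h; a higher number here means a weaker inhibitor, a lower number a stronger inhibitor:
compound 1 `COc1ccc(C(=O)c2cc(OC)c(OC)c(OC)c2)cc1N` gives 80 nM;
compound 2 `COc1ccc(/C=C/C(=O)Nc2cc(C(=O)c3cc(OC)c(OC)c(OC)c3)ccc2OC)cc1` gives 11800 nM;
compound 3 `COc1ccc(/C=C/C(=O)Nc2cc(C(=O)c3cc(OC)c(OC)c(OC)c3)cc(OC)c2OC)cc1` gives 12500 nM.

Compound 3 holds the highest number of the three in this assay. Its nearest neighbour is compound 2, and the step of a 1.1-fold higher number from compound 2 to compound 3 (0.03 log units; within the scatter) lies within the scatter. Its furthest is compound 1, whose number is far lower, and that gap lies beyond the scatter.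

Compound 4 `COc1cc(C(=O)c2cc(OC)c(OC)c(OC)c2)cc(NC(=O)/C=C/c2ccc(C(F)(F)F)cc2)c1OC` differs from compound 3 in one place: trifluoromethyl in place of methoxy on an aromatic carbon. For the measured compounds named here, none of the measured steps touches this part of the molecule. Going by the values given here, the only step measured, a 1.1-fold higher number from compound 2 to compound 3 (0.03 log units; within the scatter), concerns a change on the shared core and was within the scatter; it gives no guidance on the group that enters here. With nothing measured on the cinnamoyl aryl ring, the expectation for compound 4 rests on compound 3 alone. The step from compound 3 to compound 4 in this assay is therefore expected to be a 1.0-fold lower number from compound 3 to compound 4 (0.02 log units; within the scatter), that is, no change beyond the scatter. For compound 4 in this assay the estimate is 12000 nM, with a range from 4000 nM to 40000 nM.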

Compound 4, half-maximal inhibitory concentration: 3600 nM
Compound 4: middle estimate off by 3.3-fold (0.52 log units), on the high side; the measured number lies below the stated range.
By their numbers in this assay, from the lowest: compound 1; then compound 4; then compounds 2 and 3 (each within the scatter of the next).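

In this assay, replacing the 4-methoxyphenyl of compound 3 with 4-(trifluoromethyl)phenyl gives a 3.5-fold lower number from compound 3 to compound 4 (0.54 log units; beyond the scatter), a modest shift. For the compounds shown here, the only earlier step, a 1.1-fold higher number from compound 2 to compound 3 (0.03 log units; within the scatter), lay on the shared core and stayed within the scatter, so this is the first sign that the group on this aromatic carbon, para to a large group, can move the number beyond the scatter. Nothing measured here explains the shift.

With a single replacement at this place, the compounds shown leave open whether the shift tracks the loss of methoxy or the arrival of trifluoromethyl, and how a hydrogen, a chlorine or an amine would read there. They also leave open whether the same replacement would give a similar step with the core of compound 2.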